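Swapping a Fluorine for Chlorine on the Sulfonyl Ring

The source may hold more compounds than are shown below. What is called first, only, known or untested is meant among the compounds shown, and "the series" means these compounds.

Compound 1 `O=S(=O)(c1cccc(F)c1)c1cn(C2CCNC2)c2ccccc12` is the strongest binder of the three measured compounds in an assay on HeLa cells for displacement of a labelled ligand from 5-hydroxytryptamine receptor 6 (Homo sapiens), with a stated time of 2 h (a higher number here means a weaker inhibitor, a lower number a stronger inhibitor), giving 4.7 nM. Compound 2 `O=S(=O)(c1cccc(F)c1)c1cn(C2CCNC2)c2cc(F)ccc12` gives 18 nM, and compound 3 `O=S(=O)(c1cccc(F)c1)c1cn(C2CCNC2)c2cc(Cl)ccc12` gives 72 nM. The step of a 3.8-fold higher number from compound 1 to compound 2 (0.58 log units; beyond the scatter) and the step of a 15-fold higher number from compound 1 to compound 3 (1.19 log units; beyond the scatter) both lie beyond the scatter, so adding a halogen at that point of the shared core weakens binding, with chloro weakening it more than fluoro.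

Compound 4 `O=S(=O)(c1cccc(Cl)c1)c1cn(C2CCNC2)c2ccccc12` has not yet been measured in this assay. It differs from compound 1 by chloro in place of fluoro on an aromatic carbon. The cores of compound 1 and compound 2 differ by hydrogen in place of fluoro on an aromatic carbon. The same kind of change has already been seen once, from compound 2 to compound 3, where it reads chloro in place of fluoro on an aromatic carbon and gave a 4.0-fold higher number from compound 2 to compound 3 (0.60 log units; beyond the scatter). It is the same kind of change but not the same: in that pair the halogen sits on a ring that is part of a fused system of two rings, meta to a fused ring and para to a fused ring, whereas in compound 4 it sits on a six-membered aromatic ring of carbon only, meta to a large group.

For the measured compounds named here, because the one measured example, a 4.0-fold higher number from compound 2 to compound 3 (0.60 log units; beyond the scatter), weakened binding, a weakening is also expected here, though the different surroundings make the size less certain, and the estimated step is a 2.6-fold higher number from compound 1 to compound 4 (0.41 log units; beyond the scatter). Compound 4 is therefore expected to give about 12 nM, most likely between 4 nM and 40 nM.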

Compound 4, inhibition constant: 3.2 nM
The estimate for compound 4 lay 3.8-fold (0.57 log units) above the measured number; measured number outside the range, below it.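

Changing 3-fluorophenyl to 3-chlorophenyl gives a 1.5-fold lower number from compound 1 to compound 4 (0.17 log units; within the scatter) in this assay, so compound 4 and compound 1 cannot be told apart in this measurement, and this swap on the six-membered aromatic ring of carbon only leaves binding where it was. Chloro in place of fluoro therefore does not carry a single effect from one place in this series to another, since the swap weakens binding in one pair of compounds but not in the other: the same change on two cores in this assay, a 4.0-fold higher number (0.60 log units; beyond the scatter) from compound 2 to compound 3 and a 1.5-fold lower number (0.17 log units; within the scatter) from compound 1 to compound 4, 5.9-fold (0.77 log units) apart, beyond the scatter of two such steps. This rests on just one pair of compounds for each case, and the two swaps sit on different rings, so the result warns against transferring a step from one part of the molecule to another but does not explain why the two steps differ or predict what the swap would do elsewhere.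

The compounds shown leave open how 3-chlorophenyl would behave on the halogenated cores of compound 2 and compound 3. They also leave open whether a methyl group, a methoxy group or a nitrile could stand in the place of chloro on the core of compound 1 and give similar binding.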